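Amine exchange on the shared core: cytotoxicity notes

The compounds below may be only part of what the source reports. "The series", "measured", "known", "first", "only" and "open" are said of these compounds alone.

Compound 1 `CN(C)c1nc(Cc2c(F)cccc2F)cc(=O)[nH]1` and compound 2 `O=c1cc(Cc2c(F)cccc2F)nc(N2CCCC2)[nH]1` share a core and differ in one amino group. In an ADME assay on MT4 cells (Homo sapiens) for cytotoxicity, read by MTT assay, with a stated time of 4 days (a higher number here means that more compound is tolerated, a lower number that less compound is tolerated), compound 1 gives > 94000 nM, which is a limit and not a number. In this assay compound 2 gives > 86000 nM, which is also a limit. For the measured compounds named here, compound 2 therefore has no numerical position, and the only other value available is a limit too.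

Compound 3 `CC1CCN(c2nc(Cc3c(F)cccc3F)cc(=O)[nH]2)CC1` carries 4-methylpiperidin-1-yl in place of pyrrolidin-1-yl on an aromatic carbon, between two ring nitrogen atoms: 4-methylpiperidin-1-yl in place of pyrrolidin-1-yl on an aromatic carbon. Going by the values given here, the one measured step bearing on this change also exchanges the amino group on an aromatic carbon, with pyrrolidin-1-yl in place of dimethylamino: a step that the two limits leave unreadable from compound 1 to compound 2. That step offers neither a size nor a direction. Among the compounds with values here, no step beyond the usual scatter is therefore expected in this assay, although the range is kept wide with no number measured so far. The estimated change is an at least 1.1-fold lower number from compound 2 to compound 3 (0.05 log units; that floor lies within the scatter). Compound 3 is expected at 75000 nM, with an estimated range of 30000 nM to 100000 nM.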

Compound 3, half-maximal cytotoxic concentration: > 78000 nM
Compound 3: no number, only a limit; the forecaster's own chance of this, stated with the estimate: 65%; middle value at least 1.0-fold (0.01 log units) away from the limit.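

In this assay compound 3 gives > 78000 nM, which is a limit and not a number. The steps to compound 3 from compound 1 and from compound 2 therefore cannot be read. The compounds shown leave open whether exchanging the amino group on the shared core changes the cytotoxic concentration at all.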